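Bromo for chloro on the core of compound 3

The source may hold more compounds than are shown below. What is called first, only, known or untested is meant among the compounds shown, and "the series" means these compounds.

The series rests on the shared core of compound 1 `COc1ccc(-c2cc(=O)c3c(OC)cc(OC)cc3n2C)cc1`. In a functional assay on KOPN-8 cells (Homo sapiens) for antiproliferative activity, with a stated time of 72 h (a higher number here means that more compound is needed for the effect, a lower number that less compound is needed), compound 1 gives 30000 nM. Compound 2 `COc1ccc(-c2cc(=O)c3c(OC)cc(OC)cc3n2Cc2ccccc2)cc1` carries phenyl in place of hydrogen on a saturated chain carbon bound to the aromatic nitrogen. In this assay compound 2 is recorded only as a limit, > 17300 nM. Among the compounds with values here, the sole measured step, a step that the limit leaves unreadable from compound 1 to compound 2, therefore cannot be read, because of the limit of > 17300 nM in this assay, at which 1 of the 3 values shown sits. Compound 3 `COc1ccc(-c2c(Cl)c(=O)c3c(OC)cc(OC)cc3n2S(=O)(=O)c2ccc(OC)cc2)cc1` adds a chloro group and a (4-methoxyphenyl)sulfonyl group to the core; in this assay compound 3 gives 19100 nM, which sits within the usual scatter of the value of compound 1, so no order between compound 3 and compound 1 can be stated.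

Compound 4 `COc1ccc(-c2c(Br)c(=O)c3c(OC)cc(OC)cc3n2S(=O)(=O)c2ccc(OC)cc2)cc1` differs from compound 3 by bromo in place of chloro on an aromatic carbon. Within the data shown here, no measured step concerns this change or any halogen exchange; the one step recorded is of a different kind and is unreadable. Nothing in the numbers points to a shift in either direction beyond the scatter.

For compound 4 the expected value in this assay is 18000 nM, with a range from 8000 nM to 40000 nM. The step from compound 3 to compound 4 is thus expected to be a 1.1-fold lower number from compound 3 to compound 4 (0.03 log units; within the scatter).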

Compound 4, half-maximal effective concentration: 2580 nM
The estimate for compound 4 lay 7.0-fold (0.84 log units) above the measured number, outside the stated range (below it).
By their numbers in this assay, from the lowest: compound 4; then compounds 3 and 1 (each within the scatter of the next).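

In this assay, bromo in place of chloro on this aromatic carbon, ortho to a 4-methoxyphenyl group and two atoms from the ring nitrogen, gives a 7.4-fold lower number from compound 3 to compound 4 (0.87 log units; beyond the scatter). Within the data shown here, this is the first readable step beyond the scatter, so the halogen at this position is a place where the number responds, even though the step is modest. Chloro and bromo match in the counted features, with no ring, no hydrogen-bond donors or acceptors and no net charge, and nothing measured here bears on why the number moves with this exchange.

The compounds shown carry only chloro and bromo at this carbon, so it stays open how iodo, a nitrile or an amine would read at the same place in this assay. From the compounds shown here alone, it also stays open whether the exchange of chloro for bromo would give a similar step on a core with a methyl or benzyl group on the ring nitrogen instead of the (4-methoxyphenyl)sulfonyl group.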